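The compounds below may be only part of what the source reports. "The series", "measured", "known", "first", "only" and "open" are said of these compounds alone.

Compound 1 `O=c1c(-c2ccc(Cl)cc2)cn(C2CC2)c2cc(N3CCNCC3)c(F)cc12`: 12900 nM. Compound 2 `COc1ccc(-c2cn(C3CC3)c3cc(N4CCNCC4)c(F)cc3c2=O)cc1`: 18900 nM. Compound 3 `CN1CCN(c2cc3c(cc2F)c(=O)c(-c2cccc(Cl)c2)cn3C2CC2)CC1`: 20200 nM. Compound 4 `COc1cccc(-c2cn(C3CC3)c3cc(N4CCN(C)CC4)c(F)cc3c2=O)c1`: not yet measured.

All of these values come from a functional assay on BGC-823 cells (Homo sapiens) for antiproliferative activity, read by MTT assay, with a stated time of 48 h; a lower number here means a stronger inhibitor, a higher number a weaker inhibitor. Compound 1 and compound 2 differ in a single place, (methoxy in place of chloro on an aromatic carbon), and that change gave a 1.5-fold higher number from compound 1 to compound 2 (0.17 log units; within the scatter). Compound 3 and compound 4 differ by the same kind of change, (methoxy in place of chloro on an aromatic carbon), but here the group sits meta to a large group, whereas in compound 2 it sits para to a large group. How the core of compound 3 differs from the core of compound 1 is not broken down here. Because a 1.5-fold higher number from compound 1 to compound 2 (0.17 log units; within the scatter) stayed within the scatter, compound 4 is expected to show a step of about the same size, a 1.3-fold higher number from compound 3 to compound 4 (0.13 log units; within the scatter). The estimate for compound 4 in this assay is 27000 nM, expected to fall between 12000 nM and 60000 nM.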

Compound 4, half-maximal inhibitory concentration: 20900 nM
For compound 4 the middle estimate is 1.3-fold (0.11 log units) above the measured one, within the range that was stated.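

In this assay, putting methoxy in place of chloro gave a 1.0-fold higher number from compound 3 to compound 4 (0.01 log units; within the scatter). Set beside the earlier step, the same change looks alike on the two cores: the same change on two cores in this assay, a 1.5-fold higher number (0.17 log units; within the scatter) from compound 1 to compound 2 and a 1.0-fold higher number (0.01 log units; within the scatter) from compound 3 to compound 4, 1.4-fold (0.15 log units) apart, within the scatter of two such steps. Within the data shown here, since both steps are within the scatter, this shows only that the change left no readable mark on either core; it does not show that a real effect carries from one core to the other, and the two pairs also differ in where the group sits on the ring.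

From the compounds shown here alone, whether an amine or a carboxylic acid in that place would move the number beyond the scatter stays open. So does whether a longer chain would act alike on both cores.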